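This account rests on a few compounds, and the source may have more. Where it says the series, first, only, none or still open, it means among the compounds named here.

Measured compounds:
Compound 1 `CC(C)c1cccc(NC(=O)CCc2cccc3c2B(O)OC3)c1`: 510 nM
Compound 2 `O=C(CCc1cccc2c1B(O)OC2)Nc1cccc(-c2cccc(Cl)c2)c1`: 300 nM

In a functional assay on SK-OV-3 cells (Homo sapiens) for antiproliferative activity, read by MTT assay, with a stated time of 72 h (on this read-out higher numbers stand for weaker inhibition and lower numbers for stronger inhibition), compound 2 gives 300 nM and compound 1 gives 510 nM. These two numbers lie within the usual scatter of each other, so this assay does not separate the two compounds.

The next compound is compound 3 `O=C(CCc1cccc2c1B(O)OC2)Nc1cccc(-c2cccc(C(F)(F)F)c2)c1`. Its difference from compound 2 is trifluoromethyl in place of chloro on an aromatic carbon. In words, trifluoromethyl stands in place of chloro on an aromatic carbon, meta to a large group.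

For the measured compounds named here, only one measured step bears on this change: a 1.7-fold lower number from compound 1 to compound 2 (0.23 log units; within the scatter). That step put 3-chlorophenyl in place of isopropyl on an aromatic carbon, and it stayed within the scatter. Going by the values given here, no measured step exchanges chloro itself, so the evidence is indirect and thin. On the strength of that single step, no shift beyond the scatter is expected in this assay, and no direction can be favoured. The expected step is no change at the digits printed from compound 2 to compound 3 (within the scatter). For compound 3 the estimated value is 300 nM, with an expected range from 110 nM to 800 nM.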

Compound 3, half-maximal inhibitory concentration: 390 nM
Compound 3: the middle estimate sits 1.3-fold (0.11 log units) below what was measured, and the stated range covers the measured number.
By their numbers in this assay, from the lowest: compounds 2, 3 and 1 (each within the scatter of the next).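

In this assay, trifluoromethyl in place of chloro on an aromatic carbon, meta to a large group, gives a 1.3-fold higher number from compound 2 to compound 3 (0.11 log units; within the scatter). For the compounds shown here, this is the first direct exchange of chloro, and it shows that a single chlorine and a group of four heavy atoms cannot be told apart at this place in this assay, whereas the earlier step had only replaced isopropyl with a whole 3-chlorophenyl group. The second substituted phenyl group reads the same way against isopropyl, with 3-(trifluoromethyl)phenyl in place of isopropyl giving a 1.3-fold lower number from compound 1 to compound 3 (0.12 log units; within the scatter), so neither of the two phenyl groups is separated from isopropyl, and nothing measured here explains why these compounds read alike.

All three compounds shown stay within the scatter of one another, so it remains open whether any change at this place can move the number beyond it. An amine or a carboxylic acid in place of chloro, or a longer chain in place of isopropyl, would test that, and changes to the shared core remain untested among these compounds.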